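Pyrazole chalcone analogues: aryl exchange at the carbonyl

A few compounds are considered here, and "the series" means these few. Any claim that something is new, unique, unknown or untested is made for them only; others in the source may bear on it.

All three measured compounds were run in a functional assay on SK-OV-3 cells (Homo sapiens) for cytotoxicity, read by sulforhodamine B assay, with a stated time of 48 h, tested at 0.01 uM; on this read-out higher numbers stand for a weaker effect at the one concentration tested and lower numbers for a stronger effect.

Compound 1 `COc1cc(-c2cc(/C=C/C(=O)c3ccc(Cl)c(Cl)c3)[nH]n2)cc(OC)c1OC` gives 99%.
Compound 2 `COc1ccc(-c2cc(/C=C/C(=O)c3ccc(N)cc3)[nH]n2)cc1OC` gives 88%.
Compound 3 `COc1ccc(-c2cc(/C=C/C(=O)c3cc(OC)c(OC)c(OC)c3)[nH]n2)cc1OC` gives 97%.

Compound 1 sits at the top end of the three numbers. The number for compound 3 lies within the scatter of the number for compound 1, so nothing separates these two. Compound 2 lies beyond the scatter below compound 1, the only separation the set shows. For the measured compounds named here, no pair of the measured compounds differs in a single place, so no isolated step can be read from them.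

Compound 4 `COc1ccc(C(=O)/C=C/c2cc(-c3cc(OC)c(OC)c(OC)c3)n[nH]2)cc1OC` is the unmeasured member. It differs from compound 1 in one place: 3,4-dimethoxyphenyl in place of 3,4-dichlorophenyl on a carbonyl carbon. Compound 3, which also carries methoxy-bearing aryl groups at both ends of the shared core, gives 97% in this assay, a number within the scatter of compound 1. On that basis the exchange is expected to produce a step of a number 2 percentage points lower from compound 1 to compound 4 (within the scatter) that stays within the scatter rather than a change in either direction. Compound 4 is therefore estimated at 97% in this assay, with a range from 88% to 104%.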

Compound 4, a percentage reported as activity, at one concentration (the size of the read-out at that concentration, not a potency): 100%
Compound 4: the middle estimate sits 3 percentage points below what was measured; the measured number falls inside the stated range.
By their numbers in this assay, from the lowest: compounds 2, 3, 1 and 4 (each within the scatter of the next, the first and the last beyond it).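

In this assay, for the compounds shown here, 3,4-dimethoxyphenyl in place of 3,4-dichlorophenyl on a carbonyl carbon gives a number 1 percentage points higher from compound 1 to compound 4 (within the scatter), the first step that isolates a single change. At this position, an aryl group carrying hydrogen-bond acceptors and one carrying none are therefore not separated at the one concentration tested, although the two groups differ in their atoms and in heavy-atom count. No data on the cause of this outcome are available.

From the compounds shown here alone, whether a carboxylic acid or a longer chain on the aryl group at this carbonyl carbon would shift the number remains open. Also open, going by these compounds, is whether compound 1 and compound 4 would separate at another concentration, since a single-concentration read-out is not a potency.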